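Swapping one aromatic group: what to expect of compound 4

The source may report more compounds than this note shows. Statements on the series, on what has been measured and on what is new or still open speak of the compounds shown alone.

- compound 1 `COc1cc(C2Oc3cc([C@H]4Oc5cc(O)cc(O)c5C(=O)[C@@H]4O)ccc3OC2COC(=O)c2ccc(N)cc2)ccc1O` gives 14300 nM
- compound 2 `COc1cc(C2Oc3cc([C@H]4Oc5cc(O)cc(O)c5C(=O)[C@@H]4O)ccc3OC2COC(=O)c2cccc(Cl)c2)ccc1O` gives 14200 nM
- compound 3 `COc1cc(C2Oc3cc([C@H]4Oc5cc(O)cc(O)c5C(=O)[C@@H]4O)ccc3OC2COC(=O)c2cc(N)cc([N+](=O)[O-])c2)ccc1O` gives 200 nM
- compound 4 `COc1cc(C2Oc3cc([C@H]4Oc5cc(O)cc(O)c5C(=O)[C@@H]4O)ccc3OC2COC(=O)c2ccc(OC)c(OC)c2)ccc1O` is still unmeasured

These compounds share one core and differ only in the aromatic group on a carbonyl carbon. For the measured compounds named here, all the numbers come from a functional assay on liver (Rattus norvegicus, strain Sprague-Dawley) for inhibition, with a stated time of 1 h (a lower number here means a stronger inhibitor, a higher number a weaker inhibitor), and, at 200 nM, compound 3 is the strongest inhibitor of the three measured so far.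

The move to compound 4 is a single exchange: 3,4-dimethoxyphenyl in place of 3-amino-5-nitrophenyl on a carbonyl carbon. Compound 4 therefore gives up the group found only in compound 3.

Going by the values given here, three measured steps bear on this. Both a 72-fold lower number from compound 1 to compound 3 (1.85 log units; beyond the scatter) and a 71-fold lower number from compound 2 to compound 3 (1.85 log units; beyond the scatter) are large, and both arrive at that group. By contrast, a 1.0-fold lower number from compound 1 to compound 2 (0.00 log units; within the scatter) stays within the scatter, so two different groups gave matching numbers. Among the compounds with values here, no measured compound carries 3,4-dimethoxyphenyl, which leaves the expectation uncertain.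

A clear move back toward the numbers of compound 1 and compound 2 seems likely, though perhaps not all the way. The expected change is a 25-fold higher number from compound 3 to compound 4 (1.40 log units; beyond the scatter) toward weaker inhibition. For compound 4 the estimated value is 5000 nM with an expected range from 700 nM to 25000 nM awaiting measurement.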

Compound 4, half-maximal inhibitory concentration: 16000 nM
The estimate for compound 4 lay 3.2-fold (0.51 log units) below the measured number; the range from low to high includes it.
By their numbers in this assay, from the lowest: compound 3; then compounds 2, 1 and 4 (each within the scatter of the next).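

In this assay, the exchange at this carbonyl carbon gives an 80-fold higher number from compound 3 to compound 4 (1.90 log units; beyond the scatter), so 3,4-dimethoxyphenyl does not keep the strong inhibition seen with 3-amino-5-nitrophenyl. The other two steps, a 1.1-fold higher number from compound 2 to compound 4 (0.05 log units; within the scatter) and a 1.1-fold higher number from compound 1 to compound 4 (0.05 log units; within the scatter), both stay within the scatter, which means three differently substituted aromatic groups now give matching numbers, and compound 3 alone stands apart from them. A substituted benzene ring at this position is therefore not enough for strong inhibition here, though nothing available explains what sets 3-amino-5-nitrophenyl apart.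

The amino and nitro groups occur together in compound 3, so the compounds shown cannot tell whether one of them accounts for its number or whether both are needed. A phenyl ring carrying only a nitro group, one carrying only an amino group, and a ring with a nitrile or a carboxylic acid in place of the nitro group would each help to separate these possibilities.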